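Halogen swap at the anilide: bromo for chloro

The source may report more compounds than this note shows. Statements on the series, on what has been measured and on what is new or still open speak of the compounds shown alone.

For the measured compounds named here, compound 2 `O=C(CSc1nc(Nc2ccccc2)c2ccccc2n1)Nc1ccccc1Cl` gives 14600 nM in a functional assay on PC-3 cells (Homo sapiens) for inhibition, read by MTT assay, with a stated time of 72 h (a higher number here means a weaker inhibitor, a lower number a stronger inhibitor), the highest of the two numbers measured so far; its nearest neighbour is compound 1 `O=C(CSc1nc(Nc2ccccc2)c2ccccc2n1)Nc1ccccc1F`, which gives 12400 nM in this assay. Going by the values given here, the only step measured so far, a 1.2-fold higher number from compound 1 to compound 2 (0.07 log units; within the scatter), exchanged one halogen for another and stayed within the scatter. Compound 3 `O=C(CSc1nc(Nc2ccccc2)c2ccccc2n1)Nc1ccccc1Br` continues that line: bromo in place of chloro on an aromatic carbon. Among the compounds with values here, the earlier halogen exchange is the only measured step that bears on this change, and it moved the number by little, so for compound 3 no step beyond the scatter is expected in this assay from the number of compound 2. A value close to that of compound 2, perhaps marginally higher in keeping with the earlier direction, is expected. The estimate for compound 3 is therefore 16000 nM, with a range from 8000 nM to 32000 nM. Thus the expected step is a 1.1-fold higher number from compound 2 to compound 3 (0.04 log units; within the scatter).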

Compound 3, half-maximal inhibitory concentration: 19800 nM
For compound 3 the middle estimate is 1.2-fold (0.09 log units) below the measured one, within the range that was stated.
By their numbers in this assay, from the lowest: compounds 1, 2 and 3 (each within the scatter of the next).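

In this assay, the step of a 1.4-fold higher number from compound 2 to compound 3 (0.13 log units; within the scatter) and the step of a 1.6-fold higher number from compound 1 to compound 3 (0.20 log units; within the scatter) both stay within the scatter, so the measured step from chloro to bromo is joined by a direct one from fluoro to bromo. At this place, on an aromatic carbon ortho to a large group, fluoro, chloro and bromo therefore give numbers that this assay does not separate, which a single exchange of two halogens could not show. No measurement at hand bears on the reason for these numbers.

Still open, on these data alone, is whether a group other than a halogen at this place, such as an amine, a carboxylic acid or a longer chain, would move the number beyond the scatter. Also open, as far as these compounds go, is whether bromo or chloro elsewhere on this ring would read the same.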